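The source may hold more compounds than are shown below. What is called first, only, known or untested is meant among the compounds shown, and "the series" means these compounds.

Working notes on the series built on the shared core of compound 1 `CN(C)C(=O)c1cc2cnc(Nc3ccc(NC(=O)C4(C(=O)Nc5ccccc5F)CC4)cc3)nc2n1C1CCCC1`, in which the aryl group on the amide-type nitrogen is varied. In a functional assay on NCI-H460 cells (Homo sapiens) for inhibition, read by CCK-8 assay, with a stated time of 72 h, tested at 10 uM (a lower number here means less inhibition of growth, a higher number more inhibition of growth at the concentration tested), compound 1 gives 93.1%. Compound 2 `CN(C)C(=O)c1cc2cnc(Nc3ccc(NC(=O)C4(C(=O)Nc5cccc(O)c5)CC4)cc3)nc2n1C1CCCC1` gives 94.9% in this assay, the highest of the three numbers shown; the step of a number 1.8 percentage points higher from compound 1 to compound 2 (within the scatter) lies within the scatter. Compound 3 `CN(C)C(=O)c1cc2cnc(Nc3ccc(NC(=O)C4(C(=O)Nc5ccc(F)cc5)CC4)cc3F)nc2n1C1CCCC1` differs from compound 2 in two places; in this assay compound 3 gives 53%, well below compound 2. Compound 4 `CN(C)C(=O)c1cc2cnc(Nc3ccc(NC(=O)C4(C(=O)Nc5ccc(Cl)c(C(F)(F)F)c5)CC4)cc3)nc2n1C1CCCC1` is not yet measured; its change from compound 2 is 4-chloro-3-(trifluoromethyl)phenyl in place of 3-hydroxyphenyl on an amide-type nitrogen. Among the measured compounds shown here, the only measured step at this amide-type nitrogen is a number 1.8 percentage points higher from compound 1 to compound 2 (within the scatter), within the scatter, so no step beyond the scatter is expected in this assay from compound 2 to compound 4. Compound 4 is expected to give 88% in this assay, with a range of 70% to 98%. The expected step is therefore a number 6.9 percentage points lower from compound 2 to compound 4 (within the scatter).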

Compound 4, percent growth inhibition at one concentration: 91.9%
Estimate against measurement, compound 4: 3.9 percentage points below; the range from low to high includes it.
By their numbers in this assay, from the lowest: compound 3; then compounds 4, 1 and 2 (each within the scatter of the next).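

In this assay, the step at the amide-type nitrogen stays within the scatter even when the 3-hydroxyphenyl group, with its hydrogen-bond donor and acceptor, gives way to 4-chloro-3-(trifluoromethyl)phenyl, which has neither. The result is a number 3 percentage points lower from compound 2 to compound 4 (within the scatter) and a number 1.2 percentage points lower from compound 1 to compound 4 (within the scatter) for the same group in place of 2-fluorophenyl, so three different aryl groups at this position cannot be told apart at this single concentration. No available data explain this result.

Still open, as far as these compounds go, is whether a non-aromatic group such as cyclohexyl, or an aryl group carrying a carboxylic acid or an amine, would keep this level of growth inhibition.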